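A few compounds are considered here, and "the series" means these few. Any claim that something is new, unique, unknown or untested is made for them only; others in the source may bear on it.

Measured so far in a functional assay on MCF7 cells (Homo sapiens) for antiproliferative activity, read by CellTiter-Glo, with a stated time of 5 days; on this read-out lower numbers stand for stronger inhibition and higher numbers for weaker inhibition:
- Compound 1 `N#Cc1cc(Cl)ccc1/C(=C(\c1ccc(/C=C/C(=O)O)cc1)c1ccc2nccn2c1)C1CCC1`: 5.9 nM
- Compound 2 `O=C(O)/C=C/c1ccc(/C(=C(\c2ccccc2)C2CCC2)c2ccc(-c3cncs3)cc2)cc1`: 9.2 nM

Among the compounds with values here, at 9.2 nM, compound 2 lies within the usual scatter of compound 1, so these two values set no order between the compounds. Compound 3 `N#Cc1cc(Cl)ccc1/C(=C(\c1ccc(/C=C/C(=O)O)cc1)c1ccc(-c2cncs2)cc1)C1CCC1` is related to compound 2 by one structural change: 4-chloro-2-cyanophenyl in place of phenyl on a double-bonded chain carbon bound to a double-bonded chain carbon and a saturated ring carbon. In words, it has 4-chloro-2-cyanophenyl in place of phenyl on a double-bonded chain carbon bound to a double-bonded chain carbon and a saturated ring carbon.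

Within the data shown here, no measured pair shows this change on its own, so the data give no direct size for it. Compound 1, which carries 4-chloro-2-cyanophenyl, gives 5.9 nM, showing that a low number in this assay is possible with this group present. Little change beyond the scatter is therefore expected, with any shift more likely toward a lower number. The expected result is a 1.8-fold lower number from compound 2 to compound 3 (0.26 log units; within the scatter). For compound 3, the estimated value is 5 nM, with an expected range from 1.8 nM to 15 nM.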

Compound 3, half-maximal inhibitory concentration: 4.3 nM
Compound 3: the middle estimate sits 1.2-fold (0.07 log units) above what was measured, within the range that was stated.
By their numbers in this assay, from the lowest: compounds 3, 1 and 2 (each within the scatter of the next, the first and the last beyond it).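

In this assay, within the data shown here, the change from phenyl to 4-chloro-2-cyanophenyl on a double-bonded chain carbon bound to a double-bonded chain carbon and a saturated ring carbon now has a direct size (a 2.1-fold lower number from compound 2 to compound 3 (0.33 log units; beyond the scatter)), a modest step that the earlier compounds could not supply. With 4-chloro-2-cyanophenyl held constant, the pair that differs on a double-bonded chain carbon bound to an aromatic carbon and a double-bonded chain carbon gives a second reading (a 1.4-fold lower number from compound 1 to compound 3 (0.14 log units; within the scatter)), which sets no order between the two groups exchanged there. Nothing at hand accounts for either step.

The chlorine and the nitrile enter together in the one measured change, so the compounds shown leave open how a phenyl carrying only one of them, or a fluorine in place of the chlorine, would read in this assay. The size of the step is also known only with the group of compound 3 at the other position, and the carboxylic acid, common to all three compounds, has no comparison with an amide or an ester at that place.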